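The source may report more compounds than this note shows. Statements on the series, on what has been measured and on what is new or still open speak of the compounds shown alone.

Compound 1 `C=C1C[C@]23C[C@@]1(O)CC[C@@H]2c1cccc(C)c1[C@@H]3Cn1cc(-c2ccc(C)cc2)nn1`, compound 2 `C=C1C[C@]23C[C@@]1(O)CC[C@H]2c1ccc(O)c(C)c1[C@@H]3Cn1cc(-c2ccc(C(F)(F)F)cc2)nn1` and compound 3 `C=C1C[C@]23C[C@@]1(O)CC[C@H]2c1ccc(OS(=O)(=O)c2ccc(C)cc2)c(C)c1[C@@H]3Cn1cc(-c2ccc(C(F)(F)F)cc2)nn1` are built on a shared core and differ only in the groups carried on their aromatic rings. In a functional assay on SW480 cells (Homo sapiens) for cytotoxicity, read by MTT assay, with a stated time of 4 days (a lower number here means a stronger inhibitor, a higher number a weaker inhibitor), compound 1 gives a limit rather than a number, > 20000 nM. In this assay compound 2 likewise gives a limit, > 20000 nM. Compound 3 also gives a limit in this assay, > 20000 nM. The measured step that the two limits leave unreadable from compound 2 to compound 3 cannot be read, because both of its ends are limits. Compound 2 therefore stands at the limit of > 20000 nM in this assay, at which 3 of the 3 values shown sit, and no measured value places it at a number.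

Compound 4 `C=C1C[C@]23C[C@@]1(O)CC[C@H]2c1ccc(O)c(C)c1[C@@H]3Cn1cc(-c2ccc(Cl)cc2)nn1` differs from compound 2 by chloro in place of trifluoromethyl on an aromatic carbon. Within the data shown here, no measured step touches this part of the molecule: the only measured step, a step that the two limits leave unreadable from compound 2 to compound 3, alters the oxygen on the other aromatic ring and is itself unreadable, so nothing measured sets the size or direction of the change. With all three measured compounds at the limit, compound 4 is expected to sit at or near that limit as well, and the expected step is a step that the limit leaves unreadable from compound 2 to compound 4, not readable beyond the scatter. The estimate for compound 4 in this assay is 25000 nM, within a range from 8000 nM to 80000 nM.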

Compound 4, half-maximal inhibitory concentration: > 20000 nM
Compound 4 was reported as a limit (the forecaster's own chance of this, stated with the estimate: 80%); the middle value is on the limit's open side.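

In this assay compound 4 gives a limit, > 20000 nM. The step between compound 2 and compound 4 cannot be read, as both of its ends are limits, and compound 2 stays where it stood: the limit of > 20000 nM in this assay, at which 4 of the 4 values shown sit.

The compounds shown leave open which groups on the aromatic rings of the shared core, if any, would give a number in this assay.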